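From iodo to cyano on the aromatic ring

This account rests on a few compounds, and the source may have more. Where it says the series, first, only, none or still open, it means among the compounds named here.

Measured in a functional assay on HT-29 cells (Homo sapiens) for antiproliferative activity, with a stated time of 48 h (on this read-out lower numbers stand for an effect already at smaller amounts and higher numbers for an effect only at larger amounts of compound), so far:
Compound 1 `O=C(CCCCCCC(=O)Nc1ccc(O)cc1)NO` gives 15000 nM here
Compound 2 `O=C(CCCCCCC(=O)Nc1ccc(C(F)(F)F)cc1)NO` gives 1400 nM here
Compound 3 `O=C(CCCCCCC(=O)Nc1ccc(I)cc1)NO` gives 950 nM here

Compound 3 sits at the low end of these numbers, within the scatter of its nearest neighbour (a 1.5-fold lower number from compound 2 to compound 3 (0.17 log units; within the scatter)). The next member, compound 4 `N#Cc1ccc(NC(=O)CCCCCCC(=O)NO)cc1`, carries cyano in place of iodo on an aromatic carbon. The two large steps (an 11-fold lower number from compound 1 to compound 2 (1.03 log units; beyond the scatter); a 16-fold lower number from compound 1 to compound 3 (1.20 log units; beyond the scatter)) both start from the hydroxy group, which neither compound 3 nor compound 4 carries. Going by the values given here, the one swap that leaves hydroxy out of play is the small step already given, so no step beyond the scatter is expected in this assay here, at most a slightly higher number. The expected change is small (a 1.6-fold higher number from compound 3 to compound 4 (0.20 log units; within the scatter)). Compound 4 is estimated at 1500 nM with an expected range from 500 nM to 4500 nM in this read-out.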

Compound 4, half-maximal effective concentration: 42000 nM
The estimate for compound 4 lay 28-fold (1.45 log units) below the measured number; measured number above the stated range.
By their numbers in this assay, from the lowest: compounds 3 and 2 (each within the scatter of the next); then compound 1; then compound 4.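

In this assay, the change to cyano at this position is far from neutral (a 44-fold higher number from compound 3 to compound 4 (1.65 log units; beyond the scatter); a 30-fold higher number from compound 2 to compound 4 (1.48 log units; beyond the scatter)), although iodo and trifluoromethyl had stayed within the scatter of each other. Cyano also separates from hydroxy (a 2.8-fold higher number from compound 1 to compound 4 (0.45 log units; beyond the scatter)), so hydroxy is no longer the only group here that goes with a high number. Nothing available here accounts for this rise. From the compounds shown here alone, whether an amine or a carboxylic acid at this position would fall with iodo and trifluoromethyl or with hydroxy and cyano stays open. So does whether the cyano step would hold with a longer chain.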